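The compounds below may be only part of what the source reports. "The series", "measured", "known", "first", "only" and "open" are said of these compounds alone.

Compound 1, `CCn1c(-c2ccc(C)cc2C)cs/c1=N\C(=O)c1ccccc1`, and compound 2, `CCCn1c(-c2ccc(C)cc2C)cs/c1=N\C(=O)c1ccccc1`, share one core, while compound 3, `CCN(C(=O)c1ccccc1)c1nc(-c2ccccc2)cs1`, and the still unmeasured compound 4, `CCCN(C(=O)c1ccccc1)c1nc(-c2ccccc2)cs1`, share another; the difference between the two cores is not broken down here. The three measured compounds were tested in a functional assay on MDA-MB-231 cells (Homo sapiens), read by microscopy and transwell migration, with a stated time of 24 h; a lower number here means a stronger inhibitor, a higher number a weaker inhibitor. In this assay compound 1 gives 1950 nM, and compound 2 gives 292 nM. Compound 2 differs from compound 1 by methyl in place of hydrogen on a saturated chain carbon, two bonds along the chain from an aromatic nitrogen, and that change brought a 6.7-fold lower number from compound 1 to compound 2 (0.82 log units; beyond the scatter). In this assay compound 3 gives 533 nM, which stands second highest of the three numbers: within the scatter of compound 2, and beyond the scatter from compound 1.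

Compound 4 carries the same kind of change on the other core, namely (methyl in place of hydrogen on a saturated chain carbon, two bonds along the chain from an amide-type nitrogen). The place is not word for word the same: in the first pair the chain carbon lies two bonds along the chain from an aromatic nitrogen, in the second two bonds along the chain from an amide-type nitrogen. Going by the values given here, because the only earlier step of this kind, a 6.7-fold lower number from compound 1 to compound 2 (0.82 log units; beyond the scatter), was made on a different core, the step expected here is set smaller, at a 2.4-fold lower number from compound 3 to compound 4 (0.38 log units; beyond the scatter). Compound 4 is therefore expected to give 220 nM in this assay, most likely between 90 nM and 550 nM.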

Compound 4, half-maximal inhibitory concentration: 77 nM
Compound 4: middle estimate off by 2.9-fold (0.46 log units), on the high side; the measured number lies below the stated range.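

In this assay, putting methyl in place of hydrogen on a saturated chain carbon, two bonds along the chain from an amide-type nitrogen, turns the ethyl chain of compound 3 into a propyl chain and gives a 6.9-fold lower number from compound 3 to compound 4 (0.84 log units; beyond the scatter). Set beside the same change on the other core, the size of the step carried over from one core to the other, even though the nitrogen carrying the chain is of a different type in the two pairs: the same change on two cores in this assay, a 6.7-fold lower number (0.82 log units; beyond the scatter) from compound 1 to compound 2 and a 6.9-fold lower number (0.84 log units; beyond the scatter) from compound 3 to compound 4, 1.0-fold (0.02 log units) apart, within the scatter of two such steps This shows that, in these two pairs, going from ethyl to propyl lowered the number by a matching amount whichever of the two cores carried the chain, but two pairs make no rule for any further core, and they do not show why the added methyl has this effect or why the two steps match.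

The compounds shown leave open whether the number keeps falling with a longer chain such as butyl or turns back up, and whether a branched chain such as isopropyl would do as well as propyl. They also leave open how a propyl chain ending in an amine or a carboxylic acid would behave on either core.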